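The source may report more compounds than this note shows. Statements on the series, on what has been measured and on what is new or still open speak of the compounds shown alone.

For the measured compounds named here, compound 2, with the structure `COc1cccc(C=O)c1OCc1cn(CCCOc2ccc3ccc(=O)oc3c2)nn1`, gives in a functional assay on HT-29 cells (Homo sapiens) for cytotoxicity, read by MTT assay, with a stated time of 24 h (a higher number here means a weaker inhibitor, a lower number a stronger inhibitor), a value of 13300 nM, which is the lowest of the two numbers measured so far. Going by the values given here, the only other measured compound is compound 1, with the structure `O=Cc1cccc(OCc2cn(CCCOc3ccc4ccc(=O)oc4c3)nn2)c1`, which in this assay gives 129000 nM. Among the compounds with values here, the one measured step, a 9.7-fold lower number from compound 1 to compound 2 (0.99 log units; beyond the scatter), shows that exchanging the aromatic group carried on the oxygen on the saturated carbon can shift the number well beyond the scatter.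

Compound 3, with the structure `O=Cc1cc([N+](=O)[O-])ccc1OCc1cn(CCCOc2ccc3ccc(=O)oc3c2)nn1`, is not yet measured. It differs from compound 2 in that (2-formyl-4-nitrophenyl in place of 2-formyl-6-methoxyphenyl on an oxygen on a saturated carbon). The same oxygen is touched as in the step from compound 1 to compound 2, so that step is the only one that bears on the new change, but it concerned a different pair of groups, so its direction cannot simply be carried over. Within the data shown here, because that step was a 9.7-fold lower number from compound 1 to compound 2 (0.99 log units; beyond the scatter), a shift of comparable size in either direction is possible, and with no closer precedent a modest step is expected. For compound 3 the expected value in this assay is 25000 nM, ranging from 6000 nM to 100000 nM, which is estimated to mean a step of a 1.9-fold higher number from compound 2 to compound 3 (0.27 log units; within the scatter).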

Compound 3, half-maximal inhibitory concentration: 53600 nM
Estimate against measurement, compound 3: 2.1-fold (0.33 log units) below; low and high end bracket the measured number.
By their numbers in this assay, from the lowest: compound 2; then compound 3; then compound 1.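

In this assay, the swap of the second group on the ring matters even when the name keeps its 2-formyl part: 2-formyl-4-nitrophenyl in place of 2-formyl-6-methoxyphenyl gives a 4.0-fold higher number from compound 2 to compound 3 (0.61 log units; beyond the scatter). Compound 3 also differs clearly from the other measured compound, with a 2.4-fold lower number from compound 1 to compound 3 (0.38 log units; beyond the scatter), so the three aromatic groups on the oxygen on a saturated carbon now give three separate levels, with 2-formyl-4-nitrophenyl lying in the middle rather than matching either of the others. Nothing shown here accounts for these differences, so the numbers describe what happens at this place but not the reason for it.

From the compounds shown here alone, all three compounds carry a formyl group, so what the number would do on a plain phenyl group, or on a ring carrying an amine or a carboxylic acid instead of the formyl group, remains open. The methoxy and nitro groups are also each seen only once and always together with a formyl group, which leaves their separate contributions unresolved, as well as whether this order would hold on other cells.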